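The compounds below may be only part of what the source reports. "The series", "measured", "known", "first", "only" and "open" are said of these compounds alone.

Measured compounds in a functional assay on the whole organism (Ear) for inhibition, with Mus musculus as the target, with a stated time of 30 min, at a dose of 100 mg/kg by the intraperitoneal route; on this read-out lower numbers stand for less inhibition and higher numbers for more inhibition at the one dose given (going by the name of the read-out):
- compound 1, `N=C(N)N/N=C/c1ccc(/C=C/C(=O)c2ccc(Cl)cc2)cc1`: 56.4%
- compound 2, `N=C(N)N/N=C/c1ccc(/C=C/C(=O)c2ccc(F)cc2)cc1`: 90.7%

Compound 2 stands at the top of the two numbers in this assay; its nearest neighbour is compound 1, and the gap between them is beyond the scatter. Among the measured compounds shown here, the one measured step is a number 34.3 percentage points higher from compound 1 to compound 2 (beyond the scatter), so within this pair a chloro on the aromatic ring goes with the lower number and a fluoro with the higher.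

Compound 3, `N=C(N)N/N=C/c1ccc(/C=C/C(=O)c2ccccc2Cl)cc1`, has not yet been measured. Its change from compound 2 is 2-chlorophenyl in place of 4-fluorophenyl on a carbonyl carbon. For the measured compounds named here, the step from compound 1 to compound 2 bears on it only in part: it covers the exchange of chlorine for fluorine, but not the move of the halogen within the ring, for which no step exists. The expectation is therefore a drop in this assay, with a wide range to cover the untested placement; the expected step is a number 28.7 percentage points lower from compound 2 to compound 3 (beyond the scatter). Compound 3 is estimated at 62%, between 35% and 90%.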

Compound 3, a percentage reported as inhibition, in the whole organism at one dose (the size of the read-out at that dose, not a potency): 84.1%
Estimate against measurement, compound 3: 22.1 percentage points below; measured number inside the range.
By their numbers in this assay, from the lowest: compound 1; then compounds 3 and 2 (each within the scatter of the next).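

In this assay, moving from 4-chlorophenyl to 2-chlorophenyl on a carbonyl carbon gives a number 27.7 percentage points higher from compound 1 to compound 3 (beyond the scatter), so chlorine as such does not go with the lower number seen for compound 1; within this pair, the result depends on which chlorophenyl group is present. The other new step is a number 6.6 percentage points lower from compound 2 to compound 3 (within the scatter), so 2-chlorophenyl and 4-fluorophenyl cannot be told apart on this read-out, and a change of halogen need not lower the number when the chlorine is carried as 2-chlorophenyl. Nothing available explains why the two chlorophenyl groups differ.

Still open, on these data alone, is how 2-fluorophenyl would compare with 4-fluorophenyl, and whether a methoxy group or an amine on this phenyl ring would fit the same reading. All three numbers come from a single dose, so they leave potency unresolved.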